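A few compounds are considered here, and "the series" means these few. Any claim that something is new, unique, unknown or untested is made for them only; others in the source may bear on it.

Compound 1 `COc1ccc2c(=O)c(/C=C/C(=O)Nc3ccccc3Cl)coc2c1` — a functional assay (QGY7701 cells, Homo sapiens) for inhibition, read by MTT assay, with a stated time of 48 h; a higher number here means a weaker inhibitor, a lower number a stronger inhibitor: 23000 nM
Compound 2 `COc1ccc2c(=O)c(/C=C/C(=O)Nc3ccc(F)cc3)coc2c1` — this assay: > 100000 nM

The reading for compound 2 in this assay is a limit of the assay and not a number. On the numbers shown, compound 2 therefore stands at the weak end: the one measured step, an at least 4.3-fold higher number from compound 1 to compound 2 (0.63 log units; beyond the scatter), separates it from compound 1, and the limit of > 100000 nM in this assay, at which 1 of the 2 values shown sits, is where compound 2 sits.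

Compound 3 `COc1ccc2c(=O)c(/C=C/C(=O)Nc3ccc(C)cc3)coc2c1` has not yet been measured in this assay. It differs from compound 2 by methyl in place of fluoro on an aromatic carbon. Within the data shown here, the single measured step exchanges 2-chlorophenyl for 4-fluorophenyl, a different change, and it gives no direct guidance on methyl in place of fluoro. Among the measured compounds shown here, nothing among the measured compounds points to a large gain from this exchange, and a further loss could only show as the same limit again. For compound 3 the expected step from compound 2 is a number no higher from compound 2 to compound 3 (the limit leaves the size open), most likely reported again as a limit. Compound 3 is estimated at 100000 nM, with a range from 30000 nM to 300000 nM.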

Compound 3, half-maximal inhibitory concentration: 39300 nM
The estimate for compound 3 lay 2.5-fold (0.41 log units) above the measured number; low and high end bracket the measured number.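

Methyl in place of fluoro, on an aromatic carbon para to a large group, gives an at least 2.5-fold lower number from compound 2 to compound 3 (0.40 log units; beyond the scatter) in this assay, so this place on the ring is not indifferent to an exchange of one heavy atom for another. Going by these compounds, the reading for compound 2 is a limit of the assay and not a number, and the full size of this step stays open because of that limit: the limit of > 100000 nM in this assay, at which 1 of the 3 values shown sits. Against the 2-chlorophenyl amide, the 4-methylphenyl amide gives a 1.7-fold higher number from compound 1 to compound 3 (0.23 log units; within the scatter), so the two are not told apart, and moving the substituent from the 2-chlorophenyl arrangement to this place does not by itself carry the loss seen with 4-fluorophenyl.

What the compounds shown leave open is whether other groups at this place, such as an amine, a methoxy group, a carboxylic acid or a longer chain, would read like methyl or like fluoro. Also open, on these data alone, is how a plain phenyl ring would read on the amide nitrogen, and whether any of these differences holds outside this one cell assay.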